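This account rests on a few compounds, and the source may have more. Where it says the series, first, only, none or still open, it means among the compounds named here.

Measured so far:
Compound 1 `CCC(=O)N1CCc2nc(C#Cc3ccccc3)sc2C1` gives, in an assay on HEK293 cells for positive allosteric modulation of metabotropic glutamate receptor 5 (Homo sapiens), read by FLIPR, with a stated time of 1 h (a lower number here means that less compound is needed, a higher number that more compound is needed for the effect), only the limit of > 10000 nM.
Compound 2 `CC1CC1C(=O)N1CCc2nc(C#Cc3ccccc3)sc2C1` gives 9.4 nM in this assay.
Compound 3 `O=C(C1CC(F)C1)N1CCc2nc(C#Cc3ccccc3)sc2C1` gives 85 nM in this assay.

Of the two real numbers, compound 3 holds the higher one; its nearest neighbour is compound 2, and the gap is a 9.0-fold higher number from compound 2 to compound 3 (0.96 log units; beyond the scatter). Compound 1 sits at the limit of > 10000 nM in this assay, at which 1 of the 3 values shown sits, which is a limit and not a number.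

Compound 4 `CC1CCC(C(=O)N2CCc3nc(C#Cc4ccccc4)sc3C2)CC1` differs from compound 3 in one place: 4-methylcyclohexyl in place of 3-fluorocyclobutyl on a carbonyl carbon. Going by the values given here, two measured steps touch the same carbonyl carbon. Exchanging ethyl for a ring gave an at least 1000-fold lower number from compound 1 to compound 2 (3.02 log units; beyond the scatter) and an at least 110-fold lower number from compound 1 to compound 3 (2.07 log units; beyond the scatter), so a ring on this carbon goes with a low number. The exchange of one ring for another, a 9.0-fold higher number from compound 2 to compound 3 (0.96 log units; beyond the scatter), was modest. Among the compounds with values here, no measured compound carries a six-membered ring at this carbon, so the step in this assay is uncertain; a change no larger than the scatter, in either direction, is expected. Compound 4 is expected to give about 50 nM, between 8 nM and 400 nM. That estimate amounts to an expected step of a 1.7-fold lower number from compound 3 to compound 4 (0.23 log units; within the scatter).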

Compound 4, half-maximal effective concentration: 190 nM
Compound 4: the middle estimate sits 3.8-fold (0.58 log units) below what was measured; measured number inside the range.
By their numbers in this assay, from the lowest: compound 2; then compound 3; then compound 4. At a limit, above all of these: compound 1.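

In this assay, a ring as large as 4-methylcyclohexyl on the carbonyl carbon still goes with a far lower number than ethyl, with an at least 52-fold lower number from compound 1 to compound 4 (1.72 log units; beyond the scatter). The value of compound 1 is only a limit: the limit of > 10000 nM in this assay, at which 1 of the 4 values shown sits. Ring size still matters, with a 2.2-fold higher number from compound 3 to compound 4 (0.35 log units; beyond the scatter) and a 20-fold higher number from compound 2 to compound 4 (1.31 log units; beyond the scatter), so across these three ring compounds the number rises from 2-methylcyclopropyl through 3-fluorocyclobutyl to 4-methylcyclohexyl, while compound 1, with its ethyl, goes against any simple rule that a smaller group gives a lower number.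

Ring size cannot yet be separated from the methyl and fluorine substituents, since each ring carries its own. Going by these compounds, how a ring bearing an amine or a carboxylic acid would behave on this carbon also remains open.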